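The source may hold more compounds than are shown below. What is called first, only, known or untested is meant among the compounds shown, and "the series" means these compounds.

Of the compounds shown here, two so far have numbers in a functional assay on MKN-45 cells (Homo sapiens) for cytotoxicity, read by MTT assay, with a stated time of 72 h; a higher number here means a weaker inhibitor, a lower number a stronger inhibitor. Compound 1 `CN(C)CCCNc1nc(-c2ccc(NC(=O)Nc3ccccc3Cl)cc2)nc2c(Cl)c(Cl)sc12` gives 1330 nM. Compound 2 `CN(C)CCNc1nc(-c2ccc(NC(=O)Nc3ccccc3)cc2)nc2ccsc12` gives 1120 nM, the lower of the two numbers, but its gap to compound 1 stays within the scatter, so the two cannot be told apart. Compound 3 `CN(C)CCNc1nc(-c2ccc(NC(=O)Nc3ccc(F)cc3)cc2)nc2ccsc12` is not yet measured; it differs from compound 2 by fluoro in place of hydrogen on an aromatic carbon. Among the measured compounds shown here, no step between measured compounds covers this change, so the expectation is a step in this assay of no more than the scatter, with no set direction. Compound 3 is thus estimated at 1000 nM, with a range from 400 nM to 2500 nM, which would mean a step of a 1.1-fold lower number from compound 2 to compound 3 (0.05 log units; within the scatter).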

Compound 3, half-maximal inhibitory concentration: 330 nM
Beside the measured number, compound 3's estimate is 3.0-fold (0.48 log units) above it, outside the stated range (below it).
By their numbers in this assay, from the lowest: compound 3; then compounds 2 and 1 (each within the scatter of the next).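

In this assay, among the compounds shown here, fluoro in place of hydrogen on the six-membered aromatic ring of carbon only, para to a large group, gives a 3.4-fold lower number from compound 2 to compound 3 (0.53 log units; beyond the scatter) and so provides the first single-place step, one beyond the scatter. Compound 1 and compound 2 differ in more than one place and could not show that this position responds to substitution. Nothing available accounts for the step. Going by these compounds, whether a methoxy or trifluoromethyl group at this position gives a step of similar size remains open. Also open, on these data alone, is whether hydroxy or amino here would keep the step.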